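Compound 2 to compound 3: a further aryl exchange

A few compounds are considered here, and "the series" means these few. Any claim that something is new, unique, unknown or untested is made for them only; others in the source may bear on it.

In a functional assay on HepG2 cells (Homo sapiens) for antiproliferative activity, read by sulforhodamine B assay, with a stated time of 48 h (a lower number here means a stronger inhibitor, a higher number a weaker inhibitor), compound 1 (`COc1cccc(/C=C/C(=O)C(=Cc2cc(OC)c(OC)c(OC)c2)C(=O)/C=C/c2cccc(OC)c2OC)c1OC`) gives 220 nM and compound 2 (`COc1cccc(/C=C/C(=O)C(=Cc2ccc(O)c(F)c2)C(=O)/C=C/c2cccc(OC)c2OC)c1OC`) gives 220 nM on the same read-out. Among the measured compounds shown here, compound 2 therefore stands level with compound 1, its only measured neighbour.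

Compound 3 (`COc1cc(C=C(C(=O)/C=C/c2cccc(OC)c2OC)C(=O)/C=C/c2cccc(OC)c2OC)cc(Br)c1O`) keeps the shared core and differs from compound 2 at one place: 3-bromo-4-hydroxy-5-methoxyphenyl in place of 3-fluoro-4-hydroxyphenyl on a double-bonded chain carbon bound to a double-bonded chain carbon (3-bromo-4-hydroxy-5-methoxyphenyl in place of 3-fluoro-4-hydroxyphenyl, on a double-bonded chain carbon bound to a double-bonded chain carbon).

For the measured compounds named here, one measured step bears on this place. It shows no change at the digits printed from compound 1 to compound 2 (within the scatter) for 3-fluoro-4-hydroxyphenyl in place of 3,4,5-trimethoxyphenyl. This is a single pair, and neither measured compound carries bromine, so the evidence is thin and the range stays wide.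

No step beyond the scatter is expected in either direction. The estimated change is a 1.1-fold lower number from compound 2 to compound 3 (0.04 log units; within the scatter) in this assay on this basis. The expected value for compound 3 is 200 nM (estimated range 80 nM to 500 nM).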

Compound 3, half-maximal inhibitory concentration: 240 nM
Estimate against measurement, compound 3: 1.2-fold (0.08 log units) below; measured number inside the range.
By their numbers in this assay, from the lowest: compounds 1, 2 and 3 (each within the scatter of the next).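

In this assay the exchange to 3-bromo-4-hydroxy-5-methoxyphenyl gives a 1.1-fold higher number from compound 2 to compound 3 (0.04 log units; within the scatter) and a 1.1-fold higher number from compound 1 to compound 3 (0.04 log units; within the scatter) so both new steps stay inside the usual variation. The earlier pair showed this for one exchange only and without bromine, whereas this place, on a double-bonded chain carbon bound to a double-bonded chain carbon, now holds three different substituted phenyl groups with no step beyond the scatter among them. That holds even though the entering group has 10 heavy atoms and 2 hydrogen-bond acceptors against 8 and 1 in 3-fluoro-4-hydroxyphenyl, and nothing at hand explains why the read-out stays level across these groups.

As far as these compounds go, all three groups at this place are phenyl rings carrying oxygen substituents, so it remains open whether the level read-out would survive a phenyl ring bearing an amine or a carboxylic acid, or a longer alkyl chain in place of the ring. From the compounds shown here alone, it also remains open whether the three compounds would stay level in a read-out on any other cell line, since the comparison here rests on this assay alone.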